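This account rests on a few compounds, and the source may have more. Where it says the series, first, only, none or still open, it means among the compounds named here.

Of the compounds shown here, three have so far been measured in a functional assay on a cell-free system (plasma, Homo sapiens), with a stated time of 3 min; a lower number here means a stronger inhibitor, a higher number a weaker inhibitor. Compound 1 `O=C(NCc1cc(Cl)ccc1-n1cnnn1)[C@@H]1[C@H]2C[C@H]2CN1C(=O)[C@H](O)Cc1ccccc1` gives 1200 nM, compound 2 `O=C([C@H](O)c1ccccc1)N1CC[C@@H]2C[C@@]21C(=O)NCc1cc(Cl)ccc1-n1cnnn1` gives 1100 nM, and compound 3 `O=C(NCc1cc(Cl)ccc1-n1cnnn1)[C@@H]1[C@@H]2C[C@@H]2CN1C(=O)[C@H](O)Cc1ccccc1` gives 970 nM. All three numbers lie within the usual scatter of one another, so none stands apart. Among the measured compounds shown here, the only single-site step among them runs a 1.2-fold lower number from compound 1 to compound 3 (0.09 log units; within the scatter), and its small size fits with the fact that compounds 1 and 3 differ only in the configuration as drawn.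

Compound 4 `O=C(NCc1cc(Cl)ccc1-n1cnnn1)[C@@H]1[C@H]2C[C@H]2CN1C(=O)[C@H](O)C1CCCCC1` differs from compound 1 in one place: cyclohexyl in place of benzyl on a saturated chain carbon bound to a carbonyl carbon and an oxygen on a saturated carbon. For the measured compounds named here, no measured step bears on that swap; the one step recorded changes configuration alone. With nothing pointing either way, the expected step of no change at the digits printed from compound 1 to compound 4 (within the scatter) is none beyond the scatter. Compound 4 is therefore estimated at 1200 nM, with a range from 400 nM to 3600 nM widened for the lack of any guiding step.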

Compound 4, half-maximal inhibitory concentration: 850 nM
Compound 4: the middle estimate sits 1.4-fold (0.15 log units) above what was measured; the range from low to high includes it.
By their numbers in this assay, from the lowest: compounds 4, 3, 2 and 1 (each within the scatter of the next).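

In this assay, among the compounds shown here, replacing benzyl with cyclohexyl gives a 1.4-fold lower number from compound 1 to compound 4 (0.15 log units; within the scatter), the first measured change of group at this position. For this pair, then, the aromatic ring of benzyl can give way to a non-aromatic ring, one heavy atom smaller, with no change beyond the scatter. Nothing recorded here accounts for that outcome. As far as these compounds go, what remains open is how this position would respond to an amine, a carboxylic acid or an open chain such as isobutyl in place of the ring, and whether any ring is needed there at all.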